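A few compounds are considered here, and "the series" means these few. Any claim that something is new, unique, unknown or untested is made for them only; others in the source may bear on it.

Two compounds with a shared core, `Nc1nc(N2CCN(C(=O)COc3ccc(Cl)cc3)CC2)c2nc(CCCc3ccc(F)cc3)sc2n1` for compound 1 and `Nc1nc(N2CCN(C(=O)COc3ccc(Cl)cc3)CC2)c2nc(-c3cccnc3)sc2n1` for compound 2, have been measured in a functional assay on cells (Lymphocyte, Homo sapiens); a higher number here means a weaker inhibitor, a lower number a stronger inhibitor. Compound 1 gives 960 nM and compound 2 gives 50 nM. Among the compounds with values here, the one step between them, a 19-fold lower number from compound 1 to compound 2 (1.28 log units; beyond the scatter), is large and arises from pyridin-3-yl in place of 3-(4-fluorophenyl)propyl on an aromatic carbon. Compound 2 therefore stands with the lowest of the two numbers in this assay, its nearest neighbour being compound 1.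

Compound 3, `Nc1nc(N2CCN(C(=O)COc3ccc(Cl)cc3)CC2)c2nc(-c3ccccn3)sc2n1`, is not yet measured. It differs from compound 2 by pyridin-2-yl in place of pyridin-3-yl on an aromatic carbon. Within the data shown here, no measured step bears directly on this change: the single step available, from a much larger group to pyridin-3-yl, says nothing about moving the ring nitrogen within a pyridine. An expectation can rest only on compound 2 itself. Because compound 2 gives 50 nM, compound 3 is expected to stay in the same region, with a step of a 1.6-fold higher number from compound 2 to compound 3 (0.20 log units; within the scatter) that is not expected to exceed the scatter. The estimate for compound 3 in this assay is 80 nM, between 25 nM and 250 nM.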

Compound 3, half-maximal inhibitory concentration: 230 nM
For compound 3 the middle estimate is 2.9-fold (0.46 log units) below the measured one; the range from low to high includes it.
By their numbers in this assay, from the lowest: compound 2; then compound 3; then compound 1.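

In this assay, the place of the ring nitrogen within the pyridine proves to matter at this position, on an aromatic carbon next to the ring nitrogen and next to the ring sulfur of the five-membered aromatic ring. Pyridin-3-yl and pyridin-2-yl have the same atoms and the same counts of donors and acceptors, yet the exchange gives a 4.6-fold higher number from compound 2 to compound 3 (0.66 log units; beyond the scatter), a step the earlier pair could not reveal. Pyridin-2-yl still improves on 3-(4-fluorophenyl)propyl, with a 4.2-fold lower number from compound 1 to compound 3 (0.62 log units; beyond the scatter), so the gain over the long chain is kept in part but is not shared equally by the two pyridines, and nothing measured here accounts for the difference between them.

The compounds shown leave open whether pyridin-4-yl or a plain phenyl ring, which carries no ring nitrogen, would come closer to compound 2 or to compound 3. They also leave open whether a methyl group or an amine on the pyridin-3-yl ring would keep the number of compound 2, and how a shorter chain ending in 4-fluorophenyl would compare with compound 1.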